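Nitro for chloro on the amide-linked core

The source may hold more compounds than are shown below. What is called first, only, known or untested is meant among the compounds shown, and "the series" means these compounds.

Three members of the series have been run in a functional assay on the whole organism (strain albino) for inhibition, with Rattus norvegicus as the target, read by paw edema, with stated times of 30 min and 3 h, at a dose of 5 mg/kg by the oral route; on this read-out higher numbers stand for more inhibition at the one dose given (going by the name of the read-out) and lower numbers for less inhibition. Compound 1 `CCOC(=O)Cc1nc(N)n(C(=O)c2ccc(Cl)cc2)n1` gives 62.8%. For the measured compounds named here, compound 2 `CCOC(=O)Cc1nc(N)n(C(=O)c2ccc(OC)cc2)n1` gives 60%; the only one-place step measured so far, a number 2.8 percentage points lower from compound 1 to compound 2 (within the scatter), falls within the scatter. Compound 3 `CCOC(=O)Cc1n[nH]c(NC(=O)c2ccc(Cl)cc2)n1`, which carries its acyl group on an exocyclic amine rather than on the ring nitrogen, gives 58.5%; its gaps to compound 2 and compound 1 are both within the scatter, so the three numbers form one undifferentiated band.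

Compound 4 `CCOC(=O)Cc1n[nH]c(NC(=O)c2ccc([N+](=O)[O-])cc2)n1` is compound 3 with nitro in place of chloro on an aromatic carbon. Going by the values given here, the only comparable precedent is the substituent swap on the benzoyl ring in this assay from compound 1 to compound 2, which stayed within the scatter, though it concerns a different group and a different core; no nitro analogue has been measured at all. The expectation is therefore no step beyond the scatter in this assay. Compound 4 is expected to give 57% with a range from 45% to 69%. The step this estimate implies, a number 1.5 percentage points lower from compound 3 to compound 4 (within the scatter), is expected to stay within the scatter.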

Compound 4, a percentage reported as inhibition, in the whole organism at one dose (the size of the read-out at that dose, not a potency): 59.8%
Compound 4: the middle estimate sits 2.8 percentage points below what was measured; low and high end bracket the measured number.
By their numbers in this assay, from the lowest: compounds 3, 4, 2 and 1 (each within the scatter of the next).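

In this assay, nitro in place of chloro on the aromatic carbon para to a large group gives a number 1.3 percentage points higher from compound 3 to compound 4 (within the scatter), so on the core of compound 3 this position takes a group of 3 heavy atoms with 2 hydrogen-bond acceptors with no step beyond the scatter. With a number 2.8 percentage points lower from compound 1 to compound 2 (within the scatter) on the core of compound 1, that makes two substituent swaps on this aromatic ring, and neither separates from the scatter at the one dose given. Nothing measured bears on why the number holds across this change.

Going by these compounds, whether an amine or a carboxylic acid on this aromatic carbon would give a step beyond the scatter remains open. So does the effect of a carboxylic acid in place of the ethyl ester on the shared core.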